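Replacing a terminal amine with a hydroxyl on a lipid-modified aminoglycoside

The source may report more compounds than this note shows. Statements on the series, on what has been measured and on what is new or still open speak of the compounds shown alone.

Two compounds sharing a core carrying two nine-carbon ether chains have been measured so far. Compound 1 `CCCCCCCCCO[C@@H]1[C@@H](N)[C@@H](OCC(O)CNCCN)O[C@H](CN)[C@H]1OCCCCCCCCC` has a side chain ending in a (2-aminoethyl)amino group. In a toxicity assay on the whole organism (J774 cells) for cytotoxicity, with Mus musculus as the target, read by MTT assay, with a stated time of 24 h, tested at 30 uM (on this read-out higher numbers stand for a weaker effect at the one concentration tested and lower numbers for a stronger effect), compound 1 gives 53%. Compound 2 `CCCCCCCCCO[C@@H]1[C@@H](N)[C@@H](O[C@H]2[C@H](O)[C@@H](OCCCCCCCCC)[C@H](N)C[C@@H]2N)O[C@H](CN)[C@H]1O` carries a second amino sugar in place of that open chain; in this assay compound 2 gives 38.8%. Of the two numbers, compound 1 stands highest, and the gap down to compound 2 lies beyond the usual scatter, so compound 1 shows the weaker effect on these cells.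

Compound 3 `CCCCCCCCCO[C@@H]1[C@@H](N)[C@@H](OCC(O)CNCCO)O[C@H](CN)[C@H]1OCCCCCCCCC` has not yet been measured. It differs from compound 1 in one place: hydroxy in place of amino on a saturated chain carbon, two bonds along the chain from an amine nitrogen. Every other part of the molecule is unchanged. Among the compounds with values here, no measured pair shows this exact change, so its size can only be guessed. The change is small in atom count, and a step in this assay that stays within the scatter, or barely beyond it, seems most likely. Compound 3 is therefore expected to give 56%, with a range from 40% to 72%. This means an expected step of a number 3 percentage points higher from compound 1 to compound 3 (within the scatter), in either direction but modest.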

Compound 3, a percentage reported as activity, at one concentration (the size of the read-out at that concentration, not a potency): 10.1%
Compound 3: the middle estimate sits 45.9 percentage points above what was measured; the measured number lies below the stated range.
By their numbers in this assay, from the lowest: compound 3; then compound 2; then compound 1.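

Replacing the terminal amino with hydroxy keeps the heavy-atom count and the hydrogen-bond donor and acceptor counts the same, yet the read-out in this assay comes out a number 42.9 percentage points lower from compound 1 to compound 3 (beyond the scatter) with this single change. The two earlier compounds differ in more than one place, so they could not show what one atom can do here: on a saturated chain carbon, two bonds along the chain from an amine nitrogen, nitrogen and oxygen are far from interchangeable, and the compound with hydroxy has the much stronger effect on these cells. Nothing at hand explains why this one atom matters so much.

Going by these compounds, it remains open whether the stronger effect follows from gaining the hydroxy or from losing the amino, and a methoxy or a dimethylamino group in the same place, or a longer chain ending in hydroxy, would help to separate the two. It is also unknown whether the same swap would have a step of similar size on a different core, so the result holds for this one pair only.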